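Hydrazone aryl swap on a triazolyl-pyridine urea series

This account rests on a few compounds, and the source may have more. Where it says the series, first, only, none or still open, it means among the compounds named here.

Measured compounds:
Compound 1 `CN(C)CCn1cnnc1-c1cc(Oc2ccc(NC(=O)N/N=C/c3ccc(O)c(Br)c3)cc2F)ccn1` — 430 nM
Compound 2 `CN(C)CCn1cnnc1-c1cc(Oc2ccc(NC(=O)N/N=C/c3cccc(Cl)c3Cl)cc2F)ccn1` — 72 nM

Of the compounds shown here, two sharing one core have been measured in a functional assay on NCI-H460 cells (Homo sapiens) for cytotoxicity, read by MTT assay, with a stated time of 72 h; on this read-out higher numbers stand for weaker inhibition and lower numbers for stronger inhibition. Compound 1 gives 430 nM, the higher of the two numbers. Among the compounds with values here, compound 2 gives 72 nM, and the step of a 6.0-fold lower number from compound 1 to compound 2 (0.78 log units; beyond the scatter) is the only measured change in this small set.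

The unmeasured compound 3 `CN(C)CCn1cnnc1-c1cc(Oc2ccc(NC(=O)N/N=C/c3c(O)ccc4ccccc34)cc2F)ccn1` differs from compound 1 in one place: 2-hydroxynaphthalen-1-yl in place of 3-bromo-4-hydroxyphenyl on a carbon with a double bond to nitrogen. Within the data shown here, no measured step describes this particular exchange. Among the measured compounds shown here, the single step that exists, from compound 1 to compound 2, replaced the same group with a different aryl ring and lowered the number well beyond the scatter, so it bears on compound 3 only as a sign that this position tolerates change and that compound 1 is not the strongest point reached. On that thin basis the step of a 1.7-fold lower number from compound 1 to compound 3 (0.24 log units; within the scatter) is expected to be a modest move downward, with wide uncertainty in either direction. Compound 3 is therefore estimated at 250 nM, within a range from 60 nM to 1100 nM.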

Compound 3, half-maximal inhibitory concentration: 890 nM
The estimate for compound 3 lay 3.6-fold (0.55 log units) below the measured number, within the range that was stated.
By their numbers in this assay, from the lowest: compound 2; then compound 1; then compound 3.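

In this assay the exchange gives a 2.1-fold higher number from compound 1 to compound 3 (0.32 log units; beyond the scatter), so changing the aryl group at this position does not always lower the number, as the earlier step alone might have suggested. The contrast with the dichlorinated compound is larger, at a 12-fold higher number from compound 2 to compound 3 (1.09 log units; beyond the scatter), and the three aryl groups on the carbon with a double bond to nitrogen now place the compounds in a clear order, with compound 2 lowest and compound 3 highest, on an otherwise unchanged core. Neither the direction nor the size of these steps can be explained from what is available here.

The entering group brings both a second aromatic ring and a different hydroxyl arrangement, and the leaving group also takes its bromine with it, so these compounds cannot show which of these features accounts for the rise. A plain naphthalen-1-yl group, a 2-hydroxyphenyl group or a 3-bromophenyl group would each separate these features, while a 2-chlorophenyl or 3-chlorophenyl group would show whether the low number of compound 2 depends on having both chlorines.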